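From pyridinyl to biphenyl: cytotoxicity expected to stay low

A few compounds are considered here, and "the series" means these few. Any claim that something is new, unique, unknown or untested is made for them only; others in the source may bear on it.

Compound 2 `CCOC(=O)CCCCCOc1cccc(CN(C(=O)c2ccc(-c3ccncc3)cc2)C(C)C)c1` was examined in an ADME assay on Raji cells (Homo sapiens) for cytotoxicity, read by CellTiter-Glo and resazurin assay, with a stated time of 72 h; on this read-out lower numbers stand for an effect already at smaller amounts and higher numbers for an effect only at larger amounts of compound. In this assay compound 2 gives > 26000 nM, which is a limit of the assay. Its neighbour compound 1 `CCOC(=O)CCCCCOc1cccc(CN(C(=O)c2ccc(-c3cccc(NC(C)=O)c3)cc2)C(C)C)c1` differs from compound 2 in one place. In this assay compound 1 gives > 26000 nM, again a limit of the assay. The step that the two limits leave unreadable from compound 1 to compound 2 is therefore not readable in size, and what both compounds share is the limit of > 26000 nM in this assay, at which 2 of the 2 values shown sit.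

Compound 3 `CCOC(=O)CCCCCOc1cccc(CN(C(=O)c2ccc(-c3cccc(-c4ccccc4)c3)cc2)C(C)C)c1` is not yet measured; it differs from compound 2 by 3-phenylphenyl in place of pyridin-4-yl on an aromatic carbon. Within the data shown here, the only measured step that bears on this position leaves its size unreadable, so nothing on hand supports expecting a step beyond the scatter in this assay in either direction. Compound 3 is thus expected to give 30000 nM, with a range from 10000 nM to 80000 nM. The step that the limit leaves unreadable from compound 2 to compound 3 implied by this estimate is expected to be small, and most likely the result is again only a limit.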

Compound 3, half-maximal effective concentration: > 26000 nM
Compound 3: a limit, no number; the forecaster's own chance of this, stated with the estimate: 70%; the middle value lies beyond the limit too.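

In this assay, among these compounds, no step among compound 1, compound 2 and compound 3 can be read, and the three compounds share one result: the limit of > 26000 nM in this assay, at which 3 of the 3 values shown sit. The compounds shown leave open whether these three differ at all in this read-out, and at which concentration any effect would appear.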